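Swapping a Pyridylmethyl Tail for Phenylsulfanyl

This account rests on a few compounds, and the source may have more. Where it says the series, first, only, none or still open, it means among the compounds named here.

Of the compounds shown here, three built on one shared core have been tested in an assay for inhibition of Fatty-acid amide hydrolase 1 (Rattus norvegicus); a lower number here means a stronger inhibitor, a higher number a weaker inhibitor. Compound 1 `O=C(CCCCC#Cc1cccc(C(F)(F)F)c1)c1ncc(-c2ccccn2)o1` gives 10 nM. Compound 2 `O=C(CCCCCCc1ccc2ccccc2c1)c1ncc(-c2ccccn2)o1` gives 11 nM in this assay. Compound 3 `O=C(CCCCCCc1ccccn1)c1ncc(-c2ccccn2)o1` gives 120 nM, the highest number of the three, and its gap to compound 2 as well as to compound 1 lies beyond the usual scatter, so among these three it is the weakest inhibitor.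

Compound 4 `O=C(CCCCCSc1ccccc1)c1ncc(-c2ccccn2)o1` has not yet been measured. It differs from compound 3 in a single place: phenylsulfanyl in place of (pyridin-2-yl)methyl on a saturated chain carbon, five bonds along the chain from a carbonyl carbon. The two compounds whose tail is an aromatic ring of carbon only stand low, while compound 3, whose tail ring holds a nitrogen, stands high. Compound 4 brings back a ring of carbon only, so its number is expected to fall, with an estimated step of a 6.0-fold lower number from compound 3 to compound 4 (0.78 log units; beyond the scatter), because compound 2 gives 11 nM and compound 1 gives 10 nM. For the measured compounds named here, the change also puts sulfur where a saturated carbon stood, for which no measured pair exists here, so the expectation stays wide. Compound 4 is estimated to give 20 nM in this assay, within a range of 6 nM to 70 nM.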

Compound 4, inhibition constant: 3 nM
Estimate against measurement, compound 4: 6.7-fold (0.82 log units) above; the measured number lies below the stated range.
By their numbers in this assay, from the lowest: compound 4; then compounds 1 and 2 (each within the scatter of the next); then compound 3.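

Swapping the tail on a saturated chain carbon, five bonds along the chain from a carbonyl carbon, has a large effect in this assay, with a 40-fold lower number from compound 3 to compound 4 (1.60 log units; beyond the scatter). This position is therefore far from indifferent to what it carries, even though the leaving and entering groups match in heavy-atom count, hydrogen-bond donors, hydrogen-bond acceptors and net charge, and each holds one six-membered aromatic ring. The swap does two things at once, replacing a ring that holds a nitrogen with a ring of carbon only and placing a sulfur where a saturated carbon stood, and nothing measured here explains why the number falls so far.

The compounds shown leave open which of these two changes carries the step, since a pyridin-2-ylsulfanyl tail or a phenylmethyl tail would each make only one of them. They also leave open how the sulfur link compares with an oxygen link or a sulfone, and whether a longer chain between the carbonyl and the sulfur would keep the low number of compound 4.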